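Working notes: methyl in place of fluoro

The source may hold more compounds than are shown below. What is called first, only, known or untested is meant among the compounds shown, and "the series" means these compounds.

Of the compounds shown here, two have numbers so far. In a functional assay on A549 cells (Homo sapiens) for antiproliferative activity, read by MTT assay, with a stated time of 96 h (on this read-out lower numbers stand for stronger inhibition of growth and higher numbers for weaker inhibition of growth), compound 1 `Cc1cc(-c2ccc(F)cc2)nn1Cc1ccc(C(=O)NO)cc1` gives 11400 nM and compound 2 `Cc1cc(-c2ccc(F)cc2)n(Cc2ccc(C(=O)NO)cc2)n1` gives 33000 nM. Compound 2 therefore stands as the higher of the two numbers, with weaker inhibition of growth, and its gap to compound 1 lies beyond the scatter. The next compound is compound 3 `Cc1ccc(-c2cc(C)nn2Cc2ccc(C(=O)NO)cc2)cc1`, which departs from compound 2 in one place: methyl in place of fluoro on an aromatic carbon. This is methyl in place of fluoro on an aromatic carbon, para to a large group, so that 4-fluorophenyl becomes 4-methylphenyl. For the measured compounds named here, no measured pair shows this change, so the expectation is anchored only on compound 2 at 33000 nM. The expected step, a 1.2-fold lower number from compound 2 to compound 3 (0.07 log units; within the scatter), is small, and no shift beyond the scatter is expected in this assay in either direction. For compound 3 the estimated value is 28000 nM, with an expected range of 12000 nM to 65000 nM.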

Compound 3, concentration for 50% growth inhibition: 12400 nM
For compound 3 the middle estimate is 2.3-fold (0.35 log units) above the measured one; the range from low to high includes it.
By their numbers in this assay, from the lowest: compounds 1 and 3 (each within the scatter of the next); then compound 2.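

In this assay, for the compounds shown here, replacing 4-fluorophenyl with 4-methylphenyl gives a 2.7-fold lower number from compound 2 to compound 3 (0.43 log units; beyond the scatter) and so provides the first reading at this place on the six-membered aromatic ring. The position responds to a swap of one heavy atom for one heavy atom, even though neither group carries a hydrogen-bond donor, hydrogen-bond acceptor or net charge, but this rests on a single modest step from one pair. No available measurement bears on the origin of this step.

From the compounds shown here alone, it remains open whether a chloro, methoxy, trifluoromethyl or amine group at the same place would move the number further, or in the opposite direction. Going by these compounds, it is also open whether the same change from fluoro to methyl would give a similar step on the core of compound 1.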